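Lengthening the amide chain of compound 3

This account rests on a few compounds, and the source may have more. Where it says the series, first, only, none or still open, it means among the compounds named here.

Compound 3 `CCCCNC(=O)CC1CCc2cc(OC)c(OC)cc21` gives 27.5% in a functional assay on the whole organism (strain Wistar) for inhibition, with Rattus norvegicus as the target, read by paw edema, with stated times of 60 min and 3 h, at a dose of 100 mg/kg by the oral route; on this read-out lower numbers stand for less inhibition and higher numbers for more inhibition at the one dose given (going by the name of the read-out); compound 1 `COc1cc2c(cc1OC)C(CC(=O)O)CC2` gives 27.5% and compound 2 `COc1cc2c(cc1OC)C(CC(=O)N(C)C)CC2` gives 34.8%. Compound 3 stands level with compound 1 and only a small distance from compound 2: no change at the digits printed from compound 1 to compound 3 (within the scatter), and a number 7.3 percentage points lower from compound 2 to compound 3 (within the scatter). Compound 4 `CCCCCNC(=O)CC1CCc2cc(OC)c(OC)cc21` carries the change (methyl in place of hydrogen on a saturated chain carbon, four bonds along the chain from an amide-type nitrogen). For the measured compounds named here, no measured step touches the chain beyond the amide-type nitrogen; the recorded steps, a number 7.3 percentage points higher from compound 1 to compound 2 (within the scatter) among them, all vary the group on the carbonyl carbon and all lie within the scatter. The expected step is therefore a number 0.5 percentage points higher from compound 3 to compound 4 (within the scatter), nothing beyond the scatter in either direction. Compound 4 is estimated at 28%, within 15% to 42%.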

Compound 4, a percentage reported as inhibition, in the whole organism at one dose (the size of the read-out at that dose, not a potency): 37.7%
Compound 4: middle estimate off by 9.7 percentage points, on the low side; measured number inside the range.
By their numbers in this assay, from the lowest: compounds 1, 3, 2 and 4 (each within the scatter of the next, the first and the last beyond it).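

In this assay, for the compounds shown here, the chain beyond the amide-type nitrogen proves able to move the read-out: methyl in place of hydrogen, four bonds along the chain from that nitrogen, gives a number 10.2 percentage points higher from compound 3 to compound 4 (beyond the scatter) as the first single-place chain step beyond the scatter. Against the carboxylic acid, pentylamino gives a number 10.2 percentage points higher from compound 1 to compound 4 (beyond the scatter) and stands clear, whereas against dimethylamino it gives a number 2.9 percentage points higher from compound 2 to compound 4 (within the scatter) and does not. Nothing available here explains the step.

On these data alone, whether a hexylamino or benzylamino group on the carbonyl carbon would extend this modest gain remains open.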